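The compounds below may be only part of what the source reports. "The series", "measured", "known", "first", "only" and "open" are said of these compounds alone.

Of the compounds shown here, three built on one shared core have been measured so far. Compound 1 `Clc1ccc2c(NCCCNc3nccc(N4CCCC4)n3)ccnc2c1` is the reference point: in a physicochemical assay for solubility, read by HPLC, in phosphate buffer, with a stated time of 24 h, at pH 7.4 (a lower number here means a less soluble compound, a higher number a more soluble compound), compound 1 gives 220 nM. Compound 2 `Clc1ccc2c(NCCCCNc3nccc(Cl)n3)ccnc2c1` gives 700 nM in this assay, and compound 3 `Clc1ccc2c(NCCNc3nccc(Cl)n3)ccnc2c1` gives 900 nM. Among these three numbers compound 1 stands lowest, and the gap between compound 1 and each of the other two compounds lies beyond the usual scatter of the measurement, so compound 1 is the least soluble of the three as the numbers stand.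

Compound 4 `Clc1ccc2c(NCCCNc3nccc(N4CCNCC4)n3)ccnc2c1` has not yet been measured. It differs from compound 1 in one place: piperazin-1-yl in place of pyrrolidin-1-yl on an aromatic carbon. Within the data shown here, no pair of measured compounds shows this particular change, so the size of the step from compound 1 to compound 4 cannot be read from any measured pair and rests on expectation alone. The expectation is for a rise in solubility beyond the scatter, not a fall, and the step of a 6.8-fold higher number from compound 1 to compound 4 (0.83 log units; beyond the scatter) is what that expectation amounts to. On that basis compound 4 is estimated to give 1500 nM in this assay, with a plausible range from 400 nM to 6000 nM.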

Compound 4, solubility: 600 nM
Compound 4: the middle estimate sits 2.5-fold (0.40 log units) above what was measured; low and high end bracket the measured number.
By their numbers in this assay, from the lowest: compound 1; then compounds 4, 2 and 3 (each within the scatter of the next).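

In this assay, the aromatic carbon next to the ring nitrogen proves open to change: with piperazin-1-yl in place of pyrrolidin-1-yl, the series shows a 2.7-fold higher number from compound 1 to compound 4 (0.44 log units; beyond the scatter), a modest step, yet the only one among these compounds that can be read for a single place. The earlier compounds shown here differed from one another in more than one place, so they could say nothing about this position on its own, whereas this pair holds the rest of the molecule fixed and changes only the ring on that carbon. The entering ring is six-membered and carries a second ring nitrogen with a hydrogen-bond donor, but nothing shown ties the step to either of these features or to any other feature of the two groups.

Still open, from the compounds shown here alone, is how other groups would compare at this carbon, for example morpholin-4-yl, which has a ring oxygen, or an open-chain dimethylamino group. Also open, going by these compounds, is whether the same exchange gives a step of similar size with a longer or shorter chain, such as those of compound 2 and compound 3, which both carry chloro in this place.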